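The source may hold more compounds than are shown below. What is called first, only, known or untested is meant among the compounds shown, and "the series" means these compounds.

Compound 2 `Cc1ccc(CNc2nc(=O)c3cc(C(F)(F)F)cc([N+](=O)[O-])c3s2)n1C` stands at a limit: in an ADME assay on HEK293 cells (Homo sapiens) for cytotoxicity, read by MTT assay, with a stated time of 24 h (on this read-out higher numbers stand for lower toxicity in this test and lower numbers for higher toxicity in this test), compound 2 gives > 10000 nM, a limit of the assay and not a number. Compound 1 `O=c1nc(N2CCC(F)(F)CC2)sc2c([N+](=O)[O-])cc(C(F)(F)F)cc12` likewise reaches only a limit in this assay, > 10000 nM. Within the data shown here, the single measured step, a step that the two limits leave unreadable from compound 1 to compound 2, therefore cannot be sized, and the picture is simply that of the limit of > 10000 nM in this assay, at which 2 of the 2 values shown sit. Compound 3 `O=c1nc(NCc2ccc3c(c2)OCCO3)sc2c([N+](=O)[O-])cc(C(F)(F)F)cc12` differs from compound 2 by 2,3-dihydro-1,4-benzodioxin-6-yl in place of 1,5-dimethyl-1H-pyrrol-2-yl on a saturated chain carbon bound to a nitrogen on an aromatic ring. Among the measured compounds shown here, no measured step bears on this change with a readable size, so nothing in the data points to a step beyond the scatter in either direction. The step from compound 2 to compound 3 is expected to be a step that the limit leaves unreadable from compound 2 to compound 3. Compound 3 is thus estimated at 15000 nM in this assay, within a range from 5000 nM to 40000 nM, most likely reported again as a limit.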

Compound 3, half-maximal cytotoxic concentration: > 10000 nM
Compound 3: a limit, no number (the forecaster's own chance of this, stated with the estimate: 75%); the middle value lies beyond the limit too.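

No new step can be read from compound 2 to compound 3, and the picture stays that of a single limit: the limit of > 10000 nM in this assay, at which 3 of the 3 values shown sit. The compounds shown leave open where the actual values of compound 1, compound 2 and compound 3 lie, and whether these side chains differ at all.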